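The compounds below may be only part of what the source reports. "The series", "measured", "known", "first", "only" and "open" are said of these compounds alone.

Compound 3 `COc1cccc(-c2csc(N)c2C(=O)c2ccccc2)c1` holds the lowest of the three numbers seen so far in a functional assay on CHO cells for agonist activity at adenosine receptor A1 (Homo sapiens), read by fluorescence and ERK phosphorylation, with stated times of 30 min and 1.5 h, tested at 3 uM (on this read-out lower numbers stand for a weaker effect and higher numbers for a stronger effect at the one concentration tested), where compound 3 gives 41%. Compound 2 `Nc1scc(-c2cccc([N+](=O)[O-])c2)c1C(=O)c1ccccc1` gives 47% in this assay, and the step of a number 6 percentage points lower from compound 2 to compound 3 (within the scatter) lies within the scatter, so the two cannot be set in order. Compound 1 `Nc1scc(-c2cccc(Br)c2)c1C(=O)c1ccccc1` gives 67%, and the step of a number 26 percentage points lower from compound 1 to compound 3 (beyond the scatter) lies beyond the scatter, as does the step of a number 20 percentage points lower from compound 1 to compound 2 (beyond the scatter). Compound 4 `COc1cccc(-c2csc(N)c2C(=O)c2ccc(Cl)cc2)c1` differs from compound 3 by chloro in place of hydrogen on an aromatic carbon. Among the measured compounds shown here, every measured step exchanges the bromo, nitro or methoxy group on the other aromatic ring; no measured step touches the ring that receives the chloro, so nothing in the data bears directly on this change. The step of a number 1 percentage points higher from compound 3 to compound 4 (within the scatter) is therefore expected to stay within the scatter, with a wide range to cover the lack of a guide. Compound 4 is estimated to give 42% in this assay, between 25% and 60%.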

Compound 4, a percentage reported as activity, at one concentration (the size of the read-out at that concentration, not a potency): 58%
The estimate for compound 4 lay 16 percentage points below the measured number; the measured number falls inside the stated range.
By their numbers in this assay, from the lowest: compounds 3 and 2 (each within the scatter of the next); then compounds 4 and 1 (each within the scatter of the next).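

In this assay, among the compounds shown here, the step of a number 17 percentage points higher from compound 3 to compound 4 (beyond the scatter) shows that the ring left unchanged in the earlier compounds also affects the read-out: going from phenyl to 4-chlorophenyl moves the number beyond the scatter. Until now, only exchanges of bromo, nitro and methoxy on the other aromatic ring had shown any such effect, so chloro para to a large group is the first measured change on this side of the molecule. No evidence is available to account for this gain.

The compounds shown leave open whether chloro gives a similar step when bromo or nitro replaces the methoxy group on the other ring. They also leave open whether fluoro, methyl, an amine or a carboxylic acid at the same place would do the same.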